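The source may report more compounds than this note shows. Statements on the series, on what has been measured and on what is new or still open speak of the compounds shown alone.

Compound 3 `CCCCCCCCCCCCNC(=S)N1[C@H](CO)[C@@H](O)[C@H](O)[C@H]1CO` gives the lowest number of the three measured compounds in an assay for inhibition of beta-galactosidase (Bos taurus), read by spectrophotometry; on this read-out higher numbers stand for weaker inhibition and lower numbers for stronger inhibition: compound 3 gives 24000 nM. Its nearest neighbour is compound 2 `CCCCCCCCNC(=S)N1[C@@H](CO)[C@H](O)[C@@H](O)[C@@H]1CO`, which in this assay gives 266000 nM, and the furthest is compound 1 `CCCCNC(=S)N1[C@@H](CO)[C@H](O)[C@@H](O)[C@@H]1CO`, which in this assay gives 473000 nM. Compound 2 and compound 1 are drawn with the same ring configuration as each other, and compound 3 with the opposite one.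

Compound 4 `CCCCCCCCCCCCNC(=S)N1[C@@H](CO)[C@H](O)[C@@H](O)[C@@H]1CO` differs from compound 3 in this way: the two compounds have the same atoms and bonds and differ only in configuration as drawn: 4 of 4 stereo elements differ (all stereocentres are inverted: mirror images); a stereocentre at a saturated ring carbon is drawn R in compound 3 and S in compound 4; a stereocentre at a saturated ring carbon is drawn R in compound 3 and S in compound 4; a stereocentre at a saturated ring carbon is drawn R in compound 3 and S in compound 4; a stereocentre at a saturated ring carbon is drawn R in compound 3 and S in compound 4. Compound 4 therefore shares its ring configuration with compound 1 and compound 2.

Among the compounds with values here, the only step measured within one configuration, a 1.8-fold lower number from compound 1 to compound 2 (0.25 log units; within the scatter), concerns chain length alone and says nothing about inverting every stereocentre. Within the data shown here, no measured pair separates mirror images, so the effect of this change is open. Because compound 1 on the same configuration gives 473000 nM and compound 2 gives 266000 nM, compound 4 is expected to give a number higher than compound 3, a change of a 2.9-fold higher number from compound 3 to compound 4 (0.46 log units; beyond the scatter), though it could fall anywhere within a wide range. The estimate for compound 4 in this assay is 70000 nM, between 12000 nM and 400000 nM.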

Compound 4, half-maximal inhibitory concentration: 30000 nM
Compound 4: middle estimate off by 2.3-fold (0.37 log units), on the high side; low and high end bracket the measured number.
By their numbers in this assay, from the lowest: compounds 3 and 4 (each within the scatter of the next); then compounds 2 and 1 (each within the scatter of the next).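

In this assay, inverting every stereocentre gives a 1.3-fold higher number from compound 3 to compound 4 (0.10 log units; within the scatter), so at this chain length the read-out does not separate the two mirror images. The two compounds read alike even though all four stereocentres change, and nothing else differs to blur the comparison: the fact that compounds 3 and 4 differ only in the configuration as drawn.

Within one configuration, chain length now gives a clear step. Butyl added to the chain of compound 2 gives an 8.9-fold lower number from compound 2 to compound 4 (0.95 log units; beyond the scatter), and octyl added to the chain of compound 1 gives a 16-fold lower number from compound 1 to compound 4 (1.20 log units; beyond the scatter), whereas the earlier step, a 1.8-fold lower number from compound 1 to compound 2 (0.25 log units; within the scatter), stayed within the scatter, so the lower numbers appear only with the longest chain shown rather than at every lengthening.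

As far as these compounds go, with a single mirror-image pair, it remains open whether the butyl and octyl compounds would also read alike in the opposite configuration. From the compounds shown here alone, it is equally open whether a still longer chain would lower the number further, or whether a terminal amine or carboxylic acid on the chain would keep the number of compound 4.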